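This account rests on a few compounds, and the source may have more. Where it says the series, first, only, none or still open, it means among the compounds named here.

Compound 3 `Oc1ccc(-c2cc(-c3ccc(O)cc3)nc(-c3cccc(O)c3)c2)cc1` gives 0% in an assay on isolated protein for inhibition of DNA topoisomerase 1 (Homo sapiens), with a stated time of 30 min, tested at 100 uM; on this read-out lower numbers stand for less inhibition and higher numbers for more inhibition at the one concentration tested (going by the name of the read-out). Compound 1 `Oc1ccc(-c2cc(-c3cccc(O)c3)nc(-c3cccc(O)c3)c2)cc1` gives 0%, level with compound 3, and the two together are the lowest of the three numbers; compound 2 `Oc1cccc(-c2cc(-c3cccc(O)c3)nc(-c3ccccc3O)c2)c1` gives 1.9%, within the scatter of both. Among the measured compounds shown here, the only measured step with one difference, no change at the digits printed from compound 1 to compound 3 (within the scatter), moved nothing beyond the scatter. Compound 4 `Oc1ccc(-c2cc(-c3cccc(O)c3)nc(-c3ccccc3O)c2)cc1` differs from compound 3 by 2-hydroxyphenyl in place of 4-hydroxyphenyl on an aromatic carbon. For the measured compounds named here, this step has no measured counterpart, but compound 2, which also carries a 2-hydroxyphenyl, gives 1.9%, so no movement beyond the scatter is expected in this assay, a number 1 percentage points higher from compound 3 to compound 4 (within the scatter). Compound 4 is therefore estimated at 1%, with a range from 0% to 8%.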

Compound 4, a percentage reported as inhibition, at one concentration (the size of the read-out at that concentration, not a potency): 1.5%
Compound 4: middle estimate off by 0.5 percentage points, on the low side; low and high end bracket the measured number.
By their numbers in this assay, from the lowest: compounds 1, 3, 4 and 2 (each within the scatter of the next).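

In this assay the place next to the ring nitrogen has now been read with 2-hydroxyphenyl, 3-hydroxyphenyl and 4-hydroxyphenyl, and the steps of a number 1.5 percentage points higher from compound 3 to compound 4 (within the scatter) and a number 1.5 percentage points higher from compound 1 to compound 4 (within the scatter) show that the 2-hydroxyphenyl moves nothing beyond the scatter. The swap of 3-hydroxyphenyl for 4-hydroxyphenyl also gains a second reading on another core, a number 0.4 percentage points lower from compound 2 to compound 4 (within the scatter) and it agrees with the first: the same change on two cores in this assay, no change at the digits printed (within the scatter) from compound 1 to compound 3 and a number 0.4 percentage points lower (within the scatter) from compound 2 to compound 4, 0.4 percentage points apart, within the scatter of two such steps.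

From the compounds shown here alone, what stays open is whether an amine or a carboxylic acid at this place, in place of a hydroxyphenyl group, would give any real inhibition.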